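Removing a methyl from a fused bicyclic core: a second instance

The source may hold more compounds than are shown below. What is called first, only, known or untested is meant among the compounds shown, and "the series" means these compounds.

Measured compounds:
compound 1 `Cc1nc(C)n2c(Nc3cc[nH]n3)nccc12`, 53000 nM
compound 2 `Cc1cnc(Nc2cc[nH]n2)n2c(C)nc(C)c12`, > 48000 nM
compound 3 `CCCc1ncc2c(C)nnc(SC)n12`, > 48000 nM

In a functional assay for inhibition, with Homo sapiens as the target (on this read-out higher numbers stand for weaker inhibition and lower numbers for stronger inhibition), compound 1 gives 53000 nM. Compound 2 is reported only as a limit of this assay, namely > 48000 nM. Compound 3 likewise is reported only as a limit, > 48000 nM. The change from compound 2 to compound 1 is hydrogen in place of methyl on an aromatic carbon, and the step it made is a step that the limit leaves unreadable from compound 2 to compound 1; its size cannot be read, due to the limit of > 48000 nM in this assay, at which 2 of the 3 values shown sit.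

Compound 4 `CCCc1ncc2cnnc(SC)n12` is not yet measured. It differs from compound 3 by hydrogen in place of methyl on an aromatic carbon. This is the same kind of change as that from compound 2 to compound 1, but not the same: in compound 2 the methyl leaves a six-membered aromatic ring with 2 nitrogen, para to a (1H-pyrazol-3-yl)amino group, whereas in compound 3 it leaves a six-membered aromatic ring with 3 nitrogen, next to the ring nitrogen and para to a methylsulfanyl group. How the cores of compound 2 and compound 3 differ is not broken down here.

Among the measured compounds shown here, with compound 3 known only as a limit and the one measured instance of this change unreadable, the expectation for compound 4 rests on compound 3 alone and its limit > 48000 nM. The step expected is a step that the limit leaves unreadable from compound 3 to compound 4, which means essentially no change. Compound 4 is therefore expected to give about 80000 nM in this assay, within 20000 nM to 300000 nM, most likely again reported as a limit.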

Compound 4, half-maximal inhibitory concentration: > 48000 nM
Compound 4 ended at the assay's limit; the forecaster's own chance of this, stated with the estimate: 75%; the middle value is on the limit's open side.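

No step from compound 3 to compound 4 can be read in this assay, because both compounds are reported only as limits, and the same holds for the earlier step from compound 2 to compound 1: the limit of > 48000 nM in this assay, at which 3 of the 4 values shown sit.

The compounds shown leave open what replacing the methyl with hydrogen does to inhibition on either core, and how much weaker than their limits compound 2, compound 3 and compound 4 may be.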